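Extending the ureido group into a carboxylic acid chain

The source may report more compounds than this note shows. Statements on the series, on what has been measured and on what is new or still open speak of the compounds shown alone.

Compound 3 `N#Cc1c(-c2ccccc2)cn(-c2ccc(S(=O)(=O)Nc3ccccn3)cc2)c1NC(N)=O` gives 7340 nM in a functional assay on MCF7 cells (Homo sapiens) for inhibition, read by sulforhodamine B assay, with a stated time of 24 h; on this read-out lower numbers stand for stronger inhibition and higher numbers for weaker inhibition. Among the three measured compounds it stands second highest: its nearest neighbour is compound 2 `N#Cc1c(-c2ccccc2)cn(-c2ccc(S(=O)(=O)Nc3nccs3)cc2)c1NC(N)=O`, which gives 8050 nM, and the step of a 1.1-fold lower number from compound 2 to compound 3 (0.04 log units; within the scatter) lies within the scatter. Its furthest neighbour is compound 1 `N#Cc1c(-c2ccccc2)cn(-c2ccc(S(=O)(=O)Nc3nccs3)cc2)c1N`, which gives 3490 nM; the step of a 2.3-fold higher number from compound 1 to compound 2 (0.36 log units; beyond the scatter) goes beyond the scatter and is modest in size.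

Compound 4 `N#Cc1c(-c2ccccc2)cn(-c2ccc(S(=O)(=O)Nc3ccccn3)cc2)c1NC(=O)CCC(=O)O` differs from compound 3 by 2-carboxyethyl in place of amino on a carbonyl carbon. Going by the values given here, no measured pair alters this carbonyl carbon, so the change itself is untested here. Among the compounds with values here, the one step that touches the same part of the molecule, a 2.3-fold higher number from compound 1 to compound 2 (0.36 log units; beyond the scatter), went towards a higher number, and it concerns the ring nitrogen rather than the carbonyl carbon. This account therefore expects compound 4 to give 9500 nM in this assay, with a range from 3500 nM to 26000 nM. The expected step, a 1.3-fold higher number from compound 3 to compound 4 (0.11 log units; within the scatter), is small and may not exceed the scatter.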

Compound 4, half-maximal inhibitory concentration: 8320 nM
Compound 4: middle estimate off by 1.1-fold (0.06 log units), on the high side; low and high end bracket the measured number.
By their numbers in this assay, from the lowest: compound 1; then compounds 3, 2 and 4 (each within the scatter of the next).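

In this assay, going by these compounds alone, the step of a 1.1-fold higher number from compound 3 to compound 4 (0.05 log units; within the scatter) is the first reading of a change at this carbonyl carbon itself, and it lies within the scatter. On this read-out, then, 2-carboxyethyl and amino on the carbonyl carbon cannot be told apart, even though the change turns the ureido group into ((2-carboxyethyl)carbonyl)amino. Nothing available here bears on why the number stays within the scatter.

The compounds shown leave open whether the acid end of the chain matters at all, as against a methyl ester, an amine or a plain ethyl group in its place, and whether a longer carboxylic acid chain would read the same. Also open, going by these compounds, is whether this change reads the same with 1,3-thiazol-2-yl on the sulfonamide nitrogen, as in compound 2.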